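The source may hold more compounds than are shown below. What is called first, only, known or untested is meant among the compounds shown, and "the series" means these compounds.

Measured in a functional assay on HCT-116 cells (Homo sapiens) for antiproliferative activity, read by MTT assay, with a stated time of 48 h; a lower number here means a stronger inhibitor, a higher number a weaker inhibitor:
- Compound 1 `COc1ccc(CN(C(=O)CSc2nc3ccccc3s2)c2cc(OC)c(OC)c(OC)c2)cc1C`: 17100 nM
- Compound 2 `COc1ccc(CN(C(=O)CSc2nc3ccccc3s2)c2cc(OC)c(OC)c(OC)c2)cc1O`: 182 nM
- Compound 3 `COc1ccc(CN(C(=O)CSc2nc3c(C)cccc3s2)c2cc(OC)c(OC)c(OC)c2)cc1O`: 852 nM

Compound 2, at 182 nM, has the lowest number of the three. Compound 4 `COc1cc(N(Cc2ccc(Cl)cc2)C(=O)CSc2nc3ccccc3s2)cc(OC)c1OC` differs from it in one place: 4-chlorophenyl in place of 3-hydroxy-4-methoxyphenyl on a saturated chain carbon bound to an amide-type nitrogen. That is 4-chlorophenyl in place of 3-hydroxy-4-methoxyphenyl, so the hydroxy group is lost. The step that bears most on this is the large one, a 94-fold lower number from compound 1 to compound 2 (1.97 log units; beyond the scatter), where hydroxy replaced methyl on an aromatic carbon. The modest step of a 4.7-fold higher number from compound 2 to compound 3 (0.67 log units; beyond the scatter) is a change in the shared core and says little here. Going by the values given here, no measured compound carries chlorine, so the expectation is uncertain. The expected change is a large one toward a higher number, a 38-fold higher number from compound 2 to compound 4 (1.59 log units; beyond the scatter). For compound 4 the estimate is 7000 nM, with an expected range of 1500 nM to 30000 nM.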

Compound 4, half-maximal inhibitory concentration: 603000 nM
The estimate for compound 4 lay 86-fold (1.94 log units) below the measured number; measured number above the stated range.
By their numbers in this assay, from the lowest: compound 2; then compound 3; then compound 1; then compound 4.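

In this assay the change from 3-hydroxy-4-methoxyphenyl to 4-chlorophenyl gives a 3300-fold higher number from compound 2 to compound 4 (3.52 log units; beyond the scatter), a larger step than hydroxy in place of methyl gave. Losing the hydroxy cannot be the whole story, since compound 1 already lacks it and still the change to 4-chlorophenyl gives a 35-fold higher number from compound 1 to compound 4 (1.55 log units; beyond the scatter). No measurement here explains why this ring matters so much.

The compounds shown leave open whether the added chlorine or the lost methoxy accounts for the weaker inhibition. They also leave open whether an amine in place of the hydroxy would preserve the strength of compound 2.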